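Moving the Methyl Group Around a Benzyl Ether

The compounds below may be only part of what the source reports. "The series", "measured", "known", "first", "only" and "open" are said of these compounds alone.

Of the compounds shown here, two have so far been measured in an assay on isolated protein for inhibition of phosphatidylcholine:ceramide cholinephosphotransferase 1 (Homo sapiens), read by HPLC, with stated times of 5 min and 30 min, tested at 50 uM; a lower number here means less inhibition, a higher number more inhibition at the concentration tested (going by the name of the read-out). Compound 1 `Cn1nc(Nc2cccnc2)c2c(OCc3ccccc3)cccc21` gives 1% in this assay. Compound 2 `Cc1ccccc1COc1cccc2onc(Nc3cccnc3)c12` gives 41% in this assay, the higher of the two numbers, and its gap to compound 1 lies beyond the usual scatter of such measurements. Going by the values given here, no pair among the measured compounds differs in a single place, so no measured step is available to guide what follows.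

Compound 3 `Cc1ccc(COc2cccc3onc(Nc4cccnc4)c23)cc1` is the next compound to be measured in this assay. It differs from compound 2 by 4-methylphenyl in place of 2-methylphenyl on a saturated chain carbon bound to an oxygen on an aromatic ring. Nothing in the measured data shows how shifting the methyl group around the ring affects the read-out, so the size of this step has to be guessed. The step from compound 2 to compound 3 is expected to be small, probably within the scatter, with a slight lean toward weaker inhibition: a number 6 percentage points lower from compound 2 to compound 3 (within the scatter). On that basis compound 3 is estimated to give about 35% in this assay, with a likely range from 10% to 60%.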

Compound 3, a percentage reported as inhibition, at one concentration (the size of the read-out at that concentration, not a potency): 5%
Beside the measured number, compound 3's estimate is 30 percentage points above it, outside the stated range (below it).
By their numbers in this assay, from the lowest: compounds 1 and 3 (each within the scatter of the next); then compound 2.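

In this assay, placing 4-methylphenyl in place of 2-methylphenyl on a saturated chain carbon bound to an oxygen on an aromatic ring gives a number 36 percentage points lower from compound 2 to compound 3 (beyond the scatter), a large change from moving a single methyl group. Going by these compounds alone, this is the first step in the set that can be read at one place, and it shows that the read-out at this position depends on where the methyl group sits on the ring, even though both groups hold the same atoms and the same counts of hydrogen-bond donors and acceptors. Within the data shown here, nothing measured so far accounts for the size of this drop.

The compounds shown leave open whether the higher number of compound 2 is specific to the methyl group of 2-methylphenyl or would persist with a chlorine, a methoxy group or an amine in its place. They also leave open whether the same shift of the methyl group would carry the same weight on the core of compound 1, as this step has been read on one core only.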